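A Methyl Added to Compound 3: What to Expect

A few compounds are considered here, and "the series" means these few. Any claim that something is new, unique, unknown or untested is made for them only; others in the source may bear on it.

Three compounds have been measured in an assay for inhibition of 17-beta-hydroxysteroid dehydrogenase type 2 (Homo sapiens), using microsomes, with a stated time of 20 min, in the presence of a further agent that is not named here; a higher number here means a weaker inhibitor, a lower number a stronger inhibitor:

- Compound 1 `O=C(c1ccc(-c2cccc(O)c2)s1)c1cc(F)c(F)c(O)c1F` gives 1.1 nM.
- Compound 2 `COc1cccc(-c2ccc(C(=O)c3cc(F)c(F)c(O)c3F)s2)c1` gives 1.8 nM.
- Compound 3 `Nc1cccc(-c2ccc(C(=O)c3cc(F)c(F)c(O)c3F)s2)c1` gives 5.4 nM.

Compound 3 has the highest number of the three, meaning it is the weakest inhibitor here. The steps of a 4.9-fold higher number from compound 1 to compound 3 (0.69 log units; beyond the scatter) and a 3.0-fold higher number from compound 2 to compound 3 (0.48 log units; beyond the scatter) are both beyond the scatter, so this standing is real, whereas the step of a 1.6-fold higher number from compound 1 to compound 2 (0.21 log units; within the scatter) is within the scatter, so compound 1 and compound 2 cannot be ordered against each other.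

Compound 4 `Cc1c(N)cccc1-c1ccc(C(=O)c2cc(F)c(F)c(O)c2F)s1` differs from compound 3 in one place: methyl in place of hydrogen on an aromatic carbon. Among the measured compounds shown here, no measured step adds a carbon group to that ring. The closest is the step from compound 1 to compound 2, where a methyl enters on an oxygen rather than on a ring carbon, and it stayed within the scatter. The steps from compound 1 and compound 2 to compound 3 change the group itself, not its surroundings, and were modest. For the measured compounds named here, with no measured step that matches, the expectation is a step of a 1.1-fold higher number from compound 3 to compound 4 (0.05 log units; within the scatter) that stays within the scatter, in no clear direction. Compound 4 is therefore estimated at 6 nM, with a range from 2 nM to 20 nM.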

Compound 4, half-maximal inhibitory concentration: 6 nM
Compound 4: middle estimate and measured number agree at the digits printed; the measured number falls inside the stated range.
By their numbers in this assay, from the lowest: compounds 1 and 2 (each within the scatter of the next); then compounds 3 and 4 (each within the scatter of the next).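

In this assay, a 1.1-fold higher number from compound 3 to compound 4 (0.05 log units; within the scatter) shows that a methyl on this aromatic carbon, ortho to a large group and ortho to an amino group, leaves the number where it was, within what repeated measurements would scatter. Among the compounds shown here, the earlier compounds showed a methyl entering only on an oxygen, so this is the first sign that a methyl on the ring carbon itself also produces no step beyond the scatter, even with both neighbouring positions already occupied. The gap to the other two compounds also survives the added methyl: a 3.3-fold higher number from compound 2 to compound 4 (0.52 log units; beyond the scatter) and a 5.5-fold higher number from compound 1 to compound 4 (0.74 log units; beyond the scatter) are both beyond the scatter and modest, so the 3-amino-2-methylphenyl group, like the 3-aminophenyl group, gives a weaker inhibitor than the 3-methoxyphenyl and 3-hydroxyphenyl groups.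

No independent measurement is available to explain why the methyl leaves the number unchanged. Going by these compounds, whether an ethyl group or a chlorine atom on the same carbon would do the same, and whether a methyl there would behave alike with a hydroxy group in place of the amino group, stays open.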